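The compounds below may be only part of what the source reports. "The series", "measured", "known", "first", "only" and "open" are said of these compounds alone.

For the measured compounds named here, compound 2 `CCNC(=O)Nc1cccc(S(=O)(=O)Oc2ccccc2C)c1` gives 44000 nM in a functional assay on HT-29 cells (Homo sapiens) for cytotoxicity, read by sulforhodamine B assay, with a stated time of 48 h (a higher number here means a weaker inhibitor, a lower number a stronger inhibitor), the highest of the three numbers measured so far. Compound 3 `CCCc1ccccc1OS(=O)(=O)c1cccc(NC(=O)NCC)c1` gives 25000 nM, and the step of a 1.8-fold lower number from compound 2 to compound 3 (0.25 log units; within the scatter) lies within the scatter. Compound 1 `Cc1ccccc1OS(=O)(=O)c1cccc(NC(=O)NCCCCl)c1` gives 21000 nM, and the step of a 2.1-fold higher number from compound 1 to compound 2 (0.32 log units; beyond the scatter) is modest but beyond the scatter. Compound 4 `CCNC(=O)Nc1cccc(S(=O)(=O)Oc2ccc(O)cc2)c1` differs from compound 2 by 4-hydroxyphenyl in place of 2-methylphenyl on an oxygen. Going by the values given here, of the two measured steps, only the one from compound 2 to compound 3 alters the ring on that oxygen, and it stayed within the scatter; the one from compound 1 to compound 2 alters a chain carbon elsewhere. The expectation is therefore for no step beyond the scatter, a 1.1-fold lower number from compound 2 to compound 4 (0.04 log units; within the scatter). For compound 4 the estimate is 40000 nM, ranging from 15000 nM to 110000 nM.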

Compound 4, half-maximal inhibitory concentration: 75000 nM
Compound 4: the middle estimate sits 1.9-fold (0.27 log units) below what was measured; the measured number falls inside the stated range.
By their numbers in this assay, from the lowest: compounds 1, 3, 2 and 4 (each within the scatter of the next, the first and the last beyond it).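

Putting 4-hydroxyphenyl in place of 2-methylphenyl on the oxygen bound to the sulfonyl sulfur gives a 1.7-fold higher number from compound 2 to compound 4 (0.23 log units; within the scatter) in this assay. Earlier, only an ethyl added to the chain on this ring had been tested; here the whole group changes, gaining a hydrogen-bond donor and acceptor at the same heavy-atom count, and the step still stays within the scatter. No measurement shown accounts for this result.

The compounds shown leave open whether an amine or a carboxylic acid in place of the hydroxy group would also stay within the scatter. On these data alone, it also remains open whether 4-hydroxyphenyl would do the same on the longer chlorinated chain of compound 1.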